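Series notes: aryl change on the ring nitrogen, compound 4

This account rests on a few compounds, and the source may have more. Where it says the series, first, only, none or still open, it means among the compounds named here.

Measured so far in a functional assay on MCF7 cells (Homo sapiens) for cytotoxicity, read by MTT assay, with a stated time of 72 h; a higher number here means a weaker inhibitor, a lower number a stronger inhibitor:
compound 1 `Cn1ccc2c(Oc3ccc(NC(=O)c4nn(-c5ccc(Cl)cc5)ccc4=O)cc3F)ccnc21`: > 60000 nM, a limit of this assay, not a number
compound 2 `Cc1cc(=O)n(-c2ccc(F)cc2)nc1C(=O)Nc1ccc(Oc2ncnc3[nH]ccc23)cc1`: 4800 nM
compound 3 `Cc1cc(=O)n(-c2ccc(F)cc2)nc1C(=O)Nc1ccc(Oc2ncnc3[nH]ccc23)c(F)c1`: 24500 nM

Compound 3 holds the highest of the two numbers shown. Within the data shown here, the only measured step, a 5.1-fold higher number from compound 2 to compound 3 (0.71 log units; beyond the scatter), came with fluoro in place of hydrogen on an aromatic carbon. One value, that of compound 1, sits at the limit of > 60000 nM in this assay, at which 1 of the 3 values shown sits.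

Compound 4 `Cc1cc(=O)n(-c2ccc(Br)cc2F)nc1C(=O)Nc1ccc(Oc2ncnc3[nH]ccc23)c(F)c1` differs from compound 3 by 4-bromo-2-fluorophenyl in place of 4-fluorophenyl on an aromatic nitrogen. Among the measured compounds shown here, no measured step touches the group on the aromatic nitrogen, so the step of a 5.1-fold higher number from compound 2 to compound 3 (0.71 log units; beyond the scatter) gives no guide here, and compound 1, with a different core, shows only a limit. For compound 4 in this assay no change beyond the scatter is expected, that is a 1.0-fold higher number from compound 3 to compound 4 (0.01 log units; within the scatter). Compound 4 is therefore estimated at 25000 nM, within 8000 nM to 75000 nM.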

Compound 4, half-maximal inhibitory concentration: 26600 nM
Beside the measured number, compound 4's estimate is 1.1-fold (0.03 log units) below it; measured number inside the range.
By their numbers in this assay, from the lowest: compound 2; then compounds 3 and 4 (each within the scatter of the next). At a limit, above all of these: compound 1.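

Among these compounds, this is the first reading on the aryl group on the ring nitrogen: in this assay, 4-bromo-2-fluorophenyl in place of 4-fluorophenyl gives a 1.1-fold higher number from compound 3 to compound 4 (0.04 log units; within the scatter), so this position takes the larger aryl group with no change that can be told from the scatter. Unlike the fluoro step on the shared core, this change leaves the number where it was. Nothing shown gives a cause for this.

From the compounds shown here alone, whether an amine or a carboxylic acid on this aryl ring would move the number remains open. So does whether the same aryl change would behave alike on compound 2.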